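Swapping a Rigid Indanyl Ester for an Aryl Chain

A few compounds are considered here, and "the series" means these few. Any claim that something is new, unique, unknown or untested is made for them only; others in the source may bear on it.

Of the compounds shown here, three sharing one core have been measured in a functional assay on HEK293 cells for antagonist activity at Voltage-dependent L-type calcium channel subunit alpha-1D (Rattus norvegicus), read by FLIPR; a higher number here means a weaker inhibitor, a lower number a stronger inhibitor. Compound 1 `COC(=O)C1=C(C)NC(C)=C(C(=O)OCC(C)[N+](=O)[O-])C1c1cccc([N+](=O)[O-])c1` gives 111 nM. Compound 2 `COC(=O)C1=C(C)NC(C)=C(C(=O)OC2C=CCCC2)C1c1cccc([N+](=O)[O-])c1` gives 10 nM. Compound 3 `COC(=O)C1=C(C)NC(C)=C(C(=O)OC2Cc3ccccc3C2)C1c1cccc([N+](=O)[O-])c1` gives 43 nM, which places it second highest of the three: compound 1 sits above it, as shown by a 2.6-fold lower number from compound 1 to compound 3 (0.41 log units; beyond the scatter), while compound 2 sits below it, as shown by a 4.3-fold higher number from compound 2 to compound 3 (0.63 log units; beyond the scatter).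

Compound 4 `COC(=O)C1=C(C)NC(C)=C(C(=O)OCCCCc2ccc(OC)cc2)C1c1cccc([N+](=O)[O-])c1` is not yet measured. It differs from compound 3 in one place: 4-(4-methoxyphenyl)butyl in place of 2,3-dihydro-1H-inden-2-yl on an oxygen next to a carbonyl group. The two measured steps at this same position show that the group chosen here matters, with an 11-fold lower number from compound 1 to compound 2 (1.05 log units; beyond the scatter) being the largest move. Going by the values given here, the incoming group, a chain carrying an aromatic ring and one hydrogen-bond acceptor, does not closely match any group already tried, so the data give no direct precedent. Compound 4 is therefore expected to land within the span already seen, with a 1.4-fold lower number from compound 3 to compound 4 (0.16 log units; within the scatter) as the expected step. For compound 4 in this assay the estimate is 30 nM, with a range from 8 nM to 120 nM.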

Compound 4, half-maximal inhibitory concentration: 38 nM
For compound 4 the middle estimate is 1.3-fold (0.10 log units) below the measured one; the range from low to high includes it.
By their numbers in this assay, from the lowest: compound 2; then compounds 4 and 3 (each within the scatter of the next); then compound 1.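

In this assay, an open chain carrying an aromatic ring can take the place of a ring-closed ester group on the oxygen next to the carbonyl with no change beyond the scatter: the step is a 1.1-fold lower number from compound 3 to compound 4 (0.05 log units; within the scatter), even though 4-(4-methoxyphenyl)butyl lacks the five-membered non-aromatic ring of 2,3-dihydro-1H-inden-2-yl and adds a hydrogen-bond acceptor. The new chain still falls short of the cyclohex-2-en-1-yl group, with a 3.8-fold higher number from compound 2 to compound 4 (0.58 log units; beyond the scatter), yet it improves on the nitro-bearing chain, with a 2.9-fold lower number from compound 1 to compound 4 (0.47 log units; beyond the scatter). Nothing available explains why such different groups give matching numbers.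

Going by these compounds, the role of the methoxy oxygen remains open, and a plain 4-phenylbutyl group would test it directly. The effect of chain length is also unsettled, and a shorter 2-phenylethyl chain would begin to address it.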